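Swapping furan-2-yl for thiophen-2-yl

The source may hold more compounds than are shown below. What is called first, only, known or untested is meant among the compounds shown, and "the series" means these compounds.

In a functional assay on HeLa cells (Homo sapiens) for cytotoxicity (on this read-out higher numbers stand for weaker inhibition and lower numbers for stronger inhibition), compound 3 `O=C1C=CC(=O)c2c(Oc3ccco3)cccc21` gives 12500 nM. Compound 1 `COc1ccc2c(c1)C(=O)C=CC2=O` gives 22700 nM, which lies within the usual scatter of compound 3. Compound 2 `CC(=O)OC1=CC(=O)c2ccccc2C1=O` gives 62100 nM, a higher number and so weaker inhibition than compound 3, with a gap beyond the scatter.

Compound 4 `O=C1C=CC(=O)c2c(Oc3cccs3)cccc21` has not been measured yet. It carries thiophen-2-yl in place of furan-2-yl on an oxygen on an aromatic ring. For the measured compounds named here, no measured pair here shows this swap, so the data offer no direct guide. In this assay, the expected change is small and stays within the scatter: a 1.1-fold lower number from compound 3 to compound 4 (0.06 log units; within the scatter). Compound 4 is expected at 11000 nM, with an estimated range of 4500 nM to 27000 nM.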

Compound 4, half-maximal inhibitory concentration: 5210 nM
Estimate against measurement, compound 4: 2.1-fold (0.32 log units) above; low and high end bracket the measured number.
By their numbers in this assay, from the lowest: compound 4; then compounds 3 and 1 (each within the scatter of the next); then compound 2.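

In this assay thiophen-2-yl in place of furan-2-yl on an oxygen on an aromatic ring gives a 2.4-fold lower number from compound 3 to compound 4 (0.38 log units; beyond the scatter) and so stronger inhibition. Both groups have the same heavy-atom count and differ only in one ring atom, oxygen against sulfur, so even this small change registers at this position. Nothing available explains the gain. Going by these compounds, it remains open whether a phenyl ring or a longer carbon chain in place of thiophen-2-yl would strengthen or weaken inhibition. On these data alone, it is also open whether thiophen-2-yl would give the same gain elsewhere on the shared core.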